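Changing One Aryl Group, Paw Edema Inhibition Expected Steady

The source may hold more compounds than are shown below. What is called first, only, known or untested is meant among the compounds shown, and "the series" means these compounds.

Measured compounds:
compound 1 `CN1C[C@@H](c2ccccc2)[C@@]2(Cc3ccccc3C2=O)[C@@]12C(=O)Nc1ccccc12` gives 40%
compound 2 `CN1C[C@@H](c2cccs2)[C@@]2(Cc3ccccc3C2=O)[C@@]12C(=O)Nc1ccccc12` gives 39.1%
compound 3 `CN1C(=O)[C@@]2(c3ccccc31)N(C)C[C@@H](c1cccs1)[C@@]21Cc2ccccc2C1=O` gives 10.8%
compound 4 `COc1ccc([C@@H]2CN(C)[C@]3(C(=O)Nc4ccccc43)[C@]23Cc2ccccc2C3=O)cc1` is not yet measured

These values come from a functional assay on the whole organism (strain Wister albino) for inhibition, with Rattus norvegicus as the target, read by paw edema, with stated times of 1 h and 2 h, at a dose of 50 mg/kg by the intraperitoneal route; a lower number here means less inhibition, a higher number more inhibition at the dose given (going by the name of the read-out). Compound 2 stands second highest of the three numbers. Its nearest neighbour is compound 1: the step of a number 0.9 percentage points lower from compound 1 to compound 2 (within the scatter) is within the scatter, so the two cannot be told apart. Its furthest neighbour is compound 3: the step of a number 28.3 percentage points lower from compound 2 to compound 3 (beyond the scatter) is beyond the scatter and modest in size, and it comes from adding a methyl group to an amide-type nitrogen in a ring, a part of the structure that compound 4 leaves untouched.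

Compound 4 differs from compound 2 in one place: 4-methoxyphenyl in place of thiophen-2-yl on a saturated ring carbon

Among the measured compounds shown here, the step that bears on this change is the one from compound 1 to compound 2, where one aryl group was exchanged for another on the same saturated ring carbon with no shift beyond the scatter. For the measured compounds named here, only this single comparison is available, so the expectation rests on little. Still, on that basis the step of a number 0.1 percentage points lower from compound 2 to compound 4 (within the scatter) is expected to stay within the scatter, with no clear direction. Compound 4 is therefore estimated to give 39%, between 26% and 52%.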

Compound 4, a percentage reported as inhibition, in the whole organism at one dose (the size of the read-out at that dose, not a potency): 17.5%
The estimate for compound 4 lay 21.5 percentage points above the measured number; measured number below the stated range.
By their numbers in this assay, from the lowest: compounds 3 and 4 (each within the scatter of the next); then compounds 2 and 1 (each within the scatter of the next).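

The position on the saturated ring carbon turns out not to accept every aryl group equally in this assay: exchanging phenyl for thiophen-2-yl gave a number 0.9 percentage points lower from compound 1 to compound 2 (within the scatter), whereas 4-methoxyphenyl gives a number 21.6 percentage points lower from compound 2 to compound 4 (beyond the scatter). The comparison with the plain phenyl group isolates the change further, since adding a single methoxy group in place of a hydrogen on an aromatic carbon gives a number 22.5 percentage points lower from compound 1 to compound 4 (beyond the scatter), so among these compounds the aryl groups without a methoxy group stay together and the one carrying it stands apart. Nothing available explains why this methoxy group goes with a lower number at this dose.

From the compounds shown here alone, it remains open whether the drop belongs to methoxy itself or would come with any group on that aromatic carbon, such as a hydroxyl, a chlorine or an amine. A methoxy group on the thiophene ring, or a longer ether such as ethoxy on the phenyl ring, would help show how far the effect extends across this series.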